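Swapping a Carbonyl-Bearing Side Chain for an Ethyl Chain

A few compounds are considered here, and "the series" means these few. Any claim that something is new, unique, unknown or untested is made for them only; others in the source may bear on it.

Compound 1, `CN(C)C12CC(c3ccccc3)C(CN(C(=O)CN3CCCCC3)C1)C(c1ccccc1)C2`: 12100 nM
Compound 2, `CN1CCN(CC(=O)N2CC3C(c4ccccc4)CC(N(C)C)(CC3c3ccccc3)C2)CC1`: 9250 nM
Compound 3, `CCN(CC)CCC(=O)N1CC2C(c3ccccc3)CC(N(C)C)(CC2c2ccccc2)C1`: 15400 nM

Of the compounds shown here, three sharing one core have been measured in an ADME assay on L6 cells (Rattus norvegicus) for cytotoxicity, read by resazurin assay, with a stated time of 72 h; a higher number here means a weaker inhibitor, a lower number a stronger inhibitor. Compound 2 gives the lowest of the three numbers, yet every step among them is small: a 1.3-fold lower number from compound 1 to compound 2 (0.12 log units; within the scatter), a 1.3-fold higher number from compound 1 to compound 3 (0.10 log units; within the scatter) and a 1.7-fold higher number from compound 2 to compound 3 (0.22 log units; within the scatter), each within the scatter, so no ordering can be read from them.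

Compound 4, `CN(C)C12CC(c3ccccc3)C(CN(CCN3CCCC3)C1)C(c1ccccc1)C2`, differs from compound 2 in one place: 2-(pyrrolidin-1-yl)ethyl in place of ((4-methylpiperazin-1-yl)methyl)carbonyl on an amine nitrogen in a ring. None of the three measured steps speaks to this change directly; each of them swapped one amine-bearing group for another on a saturated chain carbon bound to a carbonyl carbon, and none moved the number beyond the scatter. The new change is broader, since the carbonyl itself leaves, so the precedent is loose and the range must be wide.

Compound 4 is expected to show a step of a 1.1-fold higher number from compound 2 to compound 4 (0.03 log units; within the scatter) in this assay, nothing beyond the scatter. Compound 4 is estimated at 10000 nM, within 4000 nM to 25000 nM.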

Compound 4, half-maximal inhibitory concentration: 5580 nM
Compound 4: the middle estimate sits 1.8-fold (0.25 log units) above what was measured, within the range that was stated.
By their numbers in this assay, from the lowest: compounds 4, 2, 1 and 3 (each within the scatter of the next, the first and the last beyond it).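

Going by these compounds alone, putting 2-(pyrrolidin-1-yl)ethyl on the amine nitrogen in a ring, in place of a carbonyl-bearing side chain, gives the first steps in this assay that lie beyond the scatter: a 2.8-fold lower number from compound 3 to compound 4 (0.44 log units; beyond the scatter) and a 2.2-fold lower number from compound 1 to compound 4 (0.34 log units; beyond the scatter), both modest. The step against the remaining carbonyl compound stays within the scatter, a 1.7-fold lower number from compound 2 to compound 4 (0.22 log units; within the scatter), so the shift does not hold against all three. Nothing measured here accounts for these steps.

Left open is whether the steps go with the loss of the carbonyl or with the pyrrolidine ring; the change carries both at once. On these data alone, a 2-(piperidin-1-yl)ethyl group on the same nitrogen would set the two apart, and how a longer chain between that nitrogen and the pyrrolidine ring would read also remains open.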